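A few compounds are considered here, and "the series" means these few. Any claim that something is new, unique, unknown or untested is made for them only; others in the source may bear on it.

In a functional assay on HeLa cells (Homo sapiens) for antiproliferative activity, read by MTT assay, with a stated time of 48 h (a lower number here means a stronger inhibitor, a higher number a weaker inhibitor), two compounds with a shared core have been measured so far. Compound 1 `COc1cccc(/C=C/C(=O)N2Cc3ccccc3[C@@H](OCc3ccccc3)[C@@H]2CO)c1OC` gives 32800 nM, and compound 2 `Cc1ccc(S(=O)(=O)NCC(=O)N2Cc3ccccc3[C@@H](OCc3ccccc3)[C@@H]2CO)cc1` gives 15100 nM. Compound 2 has the lower of the two numbers, and the gap between them lies beyond the usual scatter. Compound 3 `Cc1ccc(S(=O)(=O)N[C@@H](C)C(=O)N2Cc3ccccc3[C@@H](OCc3ccccc3)[C@@H]2CO)cc1` differs from compound 2 in one place: methyl in place of hydrogen on a saturated chain carbon bound to a carbonyl carbon and a sulfonamide nitrogen, which means methyl in place of hydrogen on a saturated chain carbon bound to a carbonyl carbon and a sulfonamide nitrogen. Among the compounds with values here, no measured pair shows what this change does, so the expectation in this assay is no step beyond the scatter, with only a slight lean towards a lower number. The expected step is a 1.2-fold lower number from compound 2 to compound 3 (0.07 log units; within the scatter). The estimated value for compound 3 is 13000 nM, with a range of 5000 nM to 32000 nM.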

Compound 3, half-maximal inhibitory concentration: 21000 nM
Compound 3: middle estimate off by 1.6-fold (0.21 log units), on the low side; the measured number falls inside the stated range.
By their numbers in this assay, from the lowest: compounds 2, 3 and 1 (each within the scatter of the next, the first and the last beyond it).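

Within the data shown here, the first pair to test this position is read in this assay and shows a 1.4-fold higher number from compound 2 to compound 3 (0.14 log units; within the scatter) when methyl replaces hydrogen on the saturated chain carbon bound to a carbonyl carbon and a sulfonamide nitrogen. Compound 2 and compound 3 therefore cannot be told apart in this assay, so the position accepts this single added carbon without a measurable effect on the number. No measurement shown explains this result.

One methyl says little about what larger groups would do, so an ethyl, an isopropyl or a benzyl group at this carbon could give a different answer. The compounds shown also leave open whether methyl with the opposite spatial arrangement at this carbon, or an amine or carboxylic acid in its place, would stay within the scatter of compound 2.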